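The source may hold more compounds than are shown below. What is called first, only, known or untested is meant among the compounds shown, and "the series" means these compounds.

Of the compounds shown here, three of a shared core have been tested in a physicochemical assay for solubility, with a stated time of 18 h, at pH 7.4; on this read-out higher numbers stand for higher solubility and lower numbers for lower solubility. Compound 1 `COc1ccc(F)cc1CNCCCNc1ccnc2cc(CC(C)C)ccc12` gives 4200 nM in this assay. Compound 2 `COc1ccc(F)cc1CNCCCNc1ccnc2cc(Oc3ccc(C(C)(C)C)cc3)ccc12` gives 14500 nM in this assay, and the step of a 3.5-fold higher number from compound 1 to compound 2 (0.54 log units; beyond the scatter) is the only one in this set that lies beyond the scatter on the rising side. Compound 3 `COc1ccc(F)cc1CNCCCNc1ccnc2cc(Cc3ccc(F)cc3Cl)ccc12` gives 4200 nM in this assay; the step of no change at the digits printed from compound 1 to compound 3 (within the scatter), while a 3.5-fold lower number from compound 2 to compound 3 (0.54 log units; beyond the scatter). Compound 3 therefore stands level with compound 1, and the two together sit at the lowest point of the three numbers, with compound 2 the furthest away.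

Compound 4 `COc1ccc(F)cc1CNCCCNc1ccnc2cc(Cc3ccc(C#N)cc3)ccc12` has not yet been measured in this assay. It differs from compound 3 by 4-cyanophenyl in place of 2-chloro-4-fluorophenyl on a saturated chain carbon bound to an aromatic carbon. For the measured compounds named here, none of the measured steps exchanges one substituted phenyl for another at this saturated chain carbon; the closest, no change at the digits printed from compound 1 to compound 3 (within the scatter), shows that putting the 2-chloro-4-fluorophenyl onto that carbon left the number unchanged, and only the move to the 4-(tert-butyl)phenoxy on an aromatic carbon shifted anything. A step of a 1.2-fold higher number from compound 3 to compound 4 (0.08 log units; within the scatter) is therefore expected, staying within the scatter. Compound 4 is estimated at 5000 nM in this assay, with a range from 2500 nM to 10000 nM.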

Compound 4, solubility: 4200 nM
Compound 4: the middle estimate sits 1.2-fold (0.08 log units) above what was measured, and the stated range covers the measured number.
By their numbers in this assay, from the lowest: compounds 1, 3 and 4 (each within the scatter of the next); then compound 2.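

For the compounds shown here, with compound 4 the saturated chain carbon bound to an aromatic carbon now carries a second substituted phenyl, so one such ring is exchanged directly for another for the first time: in this assay the result is no change at the digits printed from compound 3 to compound 4 (within the scatter) and, against the isopropyl of the first compound, no change at the digits printed from compound 1 to compound 4 (within the scatter). Isopropyl, 2-chloro-4-fluorophenyl and 4-cyanophenyl therefore stand level on this carbon, even though the entering ring swaps chlorine and fluorine for a nitrile with its hydrogen-bond acceptor, and compound 2 remains the one exception in the set, with a 3.5-fold lower number from compound 2 to compound 4 (0.54 log units; beyond the scatter) setting the 4-cyanobenzyl apart from the 4-(tert-butyl)phenoxy. Nothing available here accounts for these numbers.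

Still open, going by these compounds, is whether this levelness would hold for a carboxylic acid, a morpholine or a longer chain on the same carbon. On these data alone, it is also open whether the higher number of compound 2 goes with the phenoxy oxygen or with the tert-butyl group, which a 4-cyanophenoxy in that place would help to separate.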